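Swapping a saturated ring for a phenethyl chain next

This account rests on a few compounds, and the source may have more. Where it says the series, first, only, none or still open, it means among the compounds named here.

Measured compounds:
compound 1, `CN(Cc1cn(CC(O)COC(=O)C2CCCCC2)nn1)CC1CCCCC1`, 18%
compound 2, `CN(Cc1cn(CC(O)COC(=O)c2ccccc2)nn1)CC1CCCCC1`, 6%
compound 3, `O=C(COc1ccccc1)OC1CCCCC1n1cc(CN2CCC(c3ccccc3)CC2)nn1`, 42%

The three measured compounds were tested in an assay on nucleic acid for inhibition of Nucleic Acid, read by fluorescence, tested at 100 uM; a higher number here means more inhibition at the concentration tested (going by the name of the read-out), a lower number less inhibition. Compound 2 stands lowest of the three numbers; its nearest neighbour is compound 1, and compound 3 lies furthest above it, both gaps being beyond the scatter. Going by the values given here, the only step between compounds differing in one place is a number 12 percentage points lower from compound 1 to compound 2 (beyond the scatter), which concerns a change on a carbonyl carbon, not on the amine side.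

Compound 4, `CN(CCCc1ccccc1)Cc1cn(CC(O)COC(=O)c2ccccc2)nn1`, has not yet been measured in this assay. It differs from compound 2 as follows: phenethyl in place of cyclohexyl on a saturated chain carbon bound to an amine nitrogen. Among the compounds with values here, no measured step touches this place; compound 3 carries a phenyl as well, but within a core that differs in several places from that of compound 2, so its value bears on compound 4 only loosely. Within the data shown here, with no step at the amine side to lean on, the expected step of a number 2 percentage points higher from compound 2 to compound 4 (within the scatter) from compound 2 to compound 4 is small and may not go beyond the scatter. Compound 4 is therefore estimated at 8% in this assay, in a range from -5% to 25%.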

Compound 4, a percentage reported as inhibition, at one concentration (the size of the read-out at that concentration, not a potency): 12%
Compound 4: the middle estimate sits 4 percentage points below what was measured; the range from low to high includes it.
By their numbers in this assay, from the lowest: compounds 2, 4 and 1 (each within the scatter of the next, the first and the last beyond it); then compound 3.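

In this assay, going by these compounds alone, putting phenethyl in place of cyclohexyl on a saturated chain carbon bound to an amine nitrogen gives a number 6 percentage points higher from compound 2 to compound 4 (within the scatter), the first reading at this place. This change swaps a non-aromatic ring for an aromatic one and lengthens the chain, yet it does not move the number beyond the scatter, whereas the change on the carbonyl carbon, a number 12 percentage points lower from compound 1 to compound 2 (beyond the scatter), does. Nothing measured here offers an explanation for this result.

As far as these compounds go, the change also joins two alterations, ring type and chain length, so it remains open whether a 3-cyclohexylpropyl group or a benzyl group at this place would give a different reading, either one separating the ring from the chain. From the compounds shown here alone, compound 3, at 42%, differs from the other compounds in several places, so its number cannot be set against theirs to judge this position, and it remains open whether its phenyl-bearing amine side would behave the same way on the core of compound 2.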